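A few compounds are considered here, and "the series" means these few. Any claim that something is new, unique, unknown or untested is made for them only; others in the source may bear on it.

For the measured compounds named here, compound 1 `Cn1nc(-c2ccnc(Nc3ccc(O)cc3)n2)c2ccccc21` is the first of two measured compounds; in a functional assay on HCT-116 cells (Homo sapiens) for antiproliferative activity, read by MTT assay, with a stated time of 72 h (a lower number here means a stronger inhibitor of growth, a higher number a weaker inhibitor of growth), compound 1 gives 8430 nM. Compound 2 `Cn1nc(-c2ccnc(Nc3ccc(Cl)cc3)n2)c2ccccc21` carries chloro where compound 1 carries hydroxy, and in this assay compound 2 gives 8730 nM. The step of a 1.0-fold higher number from compound 1 to compound 2 (0.02 log units; within the scatter) shows that the two numbers cannot be told apart, so compound 2 stands level with compound 1 on the numbers shown. Compound 3 `Cn1nc(-c2ccnc(Nc3ccc([N+](=O)[O-])cc3)n2)c2ccccc21` is the next member of the series and has not yet been measured. It differs from compound 2 by nitro in place of chloro on an aromatic carbon. Going by the values given here, the only step that bears on this change is a 1.0-fold higher number from compound 1 to compound 2 (0.02 log units; within the scatter), which swapped groups at the same place without moving the number beyond the scatter. For compound 3 the expected step of a 1.0-fold lower number from compound 2 to compound 3 (0.01 log units; within the scatter) is therefore none beyond the scatter. Compound 3 is estimated at 8500 nM in this assay, with a likely range from 4000 nM to 18000 nM.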

Compound 3, concentration for 50% growth inhibition: 8220 nM
The estimate for compound 3 lay 1.0-fold (0.01 log units) above the measured number; low and high end bracket the measured number.
By their numbers in this assay, from the lowest: compounds 3, 1 and 2 (each within the scatter of the next).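

In this assay, nitro at this place, on an aromatic carbon para to a large group, gives a 1.1-fold lower number from compound 2 to compound 3 (0.03 log units; within the scatter), and the comparison with the hydroxy compound gives a 1.0-fold lower number from compound 1 to compound 3 (0.01 log units; within the scatter). Nitro has more heavy atoms and more hydrogen-bond acceptors than chloro, yet this difference leaves no mark beyond the scatter, so the three groups shown at this place cannot be told apart by their numbers. No measurement is at hand that would account for this flat result.

On these data alone, whether an amine, a carboxylic acid or a longer chain at the same place would also stay within the scatter remains open. The compounds shown also leave open whether any change to the shared core, away from this place, would move the number at all.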